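Amino in place of hydroxy: notes on compound 3

This account rests on a few compounds, and the source may have more. Where it says the series, first, only, none or still open, it means among the compounds named here.

Values in a functional assay on HCT-8 cells (Homo sapiens) for antiproliferative activity, read by MTT assay, with a stated time of 48 h; a higher number here means a weaker inhibitor, a lower number a stronger inhibitor:
- compound 1 `COc1ccc(C(=O)c2ccc(OC)c3c2OC(C)(C)C=C3)c(NC(=O)CBr)c1`: 3250 nM
- compound 2 `COc1ccc(C(=O)c2ccc(OC)c3c2OC(C)(C)C=C3)c(NC(=O)CO)c1`: 230 nM

Compound 2 has the lower of the two numbers, making it the stronger inhibitor of the pair. Compound 3 `COc1ccc(C(=O)c2ccc(OC)c3c2OC(C)(C)C=C3)c(NC(=O)CN)c1` carries amino in place of hydroxy on a saturated chain carbon bound to a carbonyl carbon. Going by the values given here, the only measured step at this place is a 14-fold lower number from compound 1 to compound 2 (1.15 log units; beyond the scatter), a large one. That step replaced bromo with hydroxy, so it does not set the size of the amino for hydroxy exchange. On these data alone, no step beyond the scatter is therefore expected, and the direction remains open. The estimated step is a 1.2-fold lower number from compound 2 to compound 3 (0.06 log units; within the scatter). In this assay the expected value for compound 3 is 200 nM, with an estimated range of 50 nM to 800 nM.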

Compound 3, half-maximal inhibitory concentration: 370 nM
Compound 3: the middle estimate sits 1.9-fold (0.27 log units) below what was measured; measured number inside the range.
By their numbers in this assay, from the lowest: compounds 2 and 3 (each within the scatter of the next); then compound 1.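

In this assay, amino and hydroxy on a saturated chain carbon bound to a carbonyl carbon cannot be told apart, with a 1.6-fold higher number from compound 2 to compound 3 (0.21 log units; within the scatter). Replacing bromo with amino also gives a clear gain, with an 8.8-fold lower number from compound 1 to compound 3 (0.94 log units; beyond the scatter), so the gain at this place is not confined to hydroxy. No evidence on hand accounts for these differences.

Still open, on these data alone, is whether a dimethylamino group at this place, or a longer chain ending in amino, would stay level with compound 2 and compound 3 or fall back towards compound 1.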